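The source may hold more compounds than are shown below. What is called first, only, known or untested is meant among the compounds shown, and "the series" means these compounds.

Compound 1 `CN(C)c1ccc(C(=O)Nc2cccc(NC(=O)COc3ccc4c(c3)OCCO4)c2)cc1` and compound 2 `CCc1ccc(C(=O)Nc2cccc(NC(=O)COc3ccc4c(=O)ccoc4c3)c2)cc1` share a core and differ in the ring carried on the ether oxygen. In an assay on isolated protein for inhibition of Rho-associated protein kinase 2 (Homo sapiens), read by scintillation counting, radiometric assay and 33P incorporation, with a stated time of 40 min, in the presence of a further agent that is not named here (on this read-out higher numbers stand for weaker inhibition and lower numbers for stronger inhibition), compound 1 gives only a limit, > 10000 nM. In this assay, among the compounds with values here, compound 2 gives 24 nM, the one value that is a number here. The value of compound 1 is a limit (the limit of > 10000 nM in this assay, at which 1 of the 2 values shown sits). Compound 3 `Cc1cc(C(=O)Nc2cccc(NC(=O)COc3ccc4c(=O)ccoc4c3)c2)ccc1C(F)(F)F` differs from compound 2 by a group of 11 heavy atoms (8 carbon, 3 fluorine; one six-membered aromatic ring of carbon only) in place of a group of 8 heavy atoms (8 carbon; one six-membered aromatic ring of carbon only), on a carbonyl carbon. Within the data shown here, no step between measured compounds is available; the expected step is small, within the scatter, in no fixed direction. Compound 3 is expected to give about 30 nM, between 8 nM and 120 nM. The expected step is a 1.3-fold higher number from compound 2 to compound 3 (0.10 log units; within the scatter).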

Compound 3, half-maximal inhibitory concentration: 43 nM
The estimate for compound 3 lay 1.4-fold (0.16 log units) below the measured number; the range from low to high includes it.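

In this assay, the step of a 1.8-fold higher number from compound 2 to compound 3 (0.25 log units; within the scatter) shows that the 4-ethylphenyl group on the carbonyl carbon can give way to the larger group carrying fluorine, with its six-membered aromatic ring of carbon only, without a change beyond the scatter. Compound 2 alone could not show how this position responds to any change. Nothing measured here accounts for the size of this step. From the compounds shown here alone, what remains open is how this position would respond to an amine or a carboxylic acid on that ring, or to a saturated ring in its place.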